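One amide group exchanged: compound 3 to compound 4

A few compounds are considered here, and "the series" means these few. Any claim that something is new, unique, unknown or untested is made for them only; others in the source may bear on it.

Measured in a functional assay on DLD-1 cells (Homo sapiens) for antiproliferative activity, read by sulforhodamine B assay, with a stated time of 48 h (a higher number here means a weaker inhibitor, a lower number a stronger inhibitor), so far:
- compound 1 `CCCCN(C)C(=O)CCCCOc1cc(OC)c(OC)c2oc(-c3ccc(OC)cc3)c(O)c(=O)c12` gives 17400 nM
- compound 2 `COc1ccc(-c2oc3c(OC)c(OC)cc(OCCCCC(=O)N4CCN(C)CC4)c3c(=O)c2O)cc1` gives > 40000 nM which is a limit of the assay and not a number
- compound 3 `COc1ccc(-c2oc3c(OC)c(OC)cc(OCCCCCC(=O)N4CCN(C)CC4)c3c(=O)c2O)cc1` gives 13700 nM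

Compound 3 at 13700 nM stands level with compound 1 at 17400 nM within the scatter. The limit value stands apart, with an at least 2.9-fold lower number from compound 2 to compound 3 (0.46 log units; beyond the scatter) beyond the scatter.

Compound 4 `COc1ccc(-c2oc3c(OC)c(OC)cc(OCCCCCC(=O)NCc4ccccn4)c3c(=O)c2O)cc1` keeps the shared core and carries ((pyridin-2-yl)methyl)amino in place of 4-methylpiperazin-1-yl on a carbonyl carbon as its only difference.

Among the measured compounds shown here, no measured compound carries the entering group. The closest exchange on a carbonyl carbon is an at least 2.2-fold higher number from compound 1 to compound 2 (0.36 log units; beyond the scatter) and it shows that such a swap can move the number. Yet a 1.3-fold lower number from compound 1 to compound 3 (0.10 log units; within the scatter) also alters the amide end and stays within the scatter. In this assay no step beyond the scatter is therefore expected, and the estimated step is a 1.0-fold higher number from compound 3 to compound 4 (0.01 log units; within the scatter) in this reading. For compound 4 the expected value is 14000 nM with an estimated range from 6000 nM to 35000 nM on this evidence.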

Compound 4, half-maximal inhibitory concentration: > 40000 nM
Compound 4: only a limit was reported; the forecaster's own chance of this, stated with the estimate: 15%; at least 2.8-fold (0.45 log units) between middle value and limit.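

In this assay, compound 4 gives > 40000 nM, which is a limit of the assay and not a number. With ((pyridin-2-yl)methyl)amino in place of 4-methylpiperazin-1-yl on a carbonyl carbon, the result is an at least 2.9-fold higher number from compound 3 to compound 4 (0.46 log units; beyond the scatter), so at this chain length the amine part of the amide alone can carry a step beyond the scatter. The comparison with the butyl(methyl)carbamoyl end points the same way, at an at least 2.2-fold higher number from compound 1 to compound 4 (0.36 log units; beyond the scatter).

The step linking compound 2 and compound 4 cannot be read because both values stand at the limit: the limit of > 40000 nM in this assay, at which 2 of the 4 values shown sit. From the compounds shown here alone, whether benzylamino, which has a plain phenyl ring in place of the pyridine, would read like compound 3 or like compound 4 remains open.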